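Hydroxy in Place of Amino: An Expected Loss of Potency

A few compounds are considered here, and "the series" means these few. Any claim that something is new, unique, unknown or untested is made for them only; others in the source may bear on it.

Compound 1 `Nc1nc(N)c2c(Sc3ccc4ccccc4c3)cccc2n1` is the more potent of the two compounds measured in an assay for inhibition of Dihydrofolate reductase (Homo sapiens) (on this read-out higher numbers stand for higher potency (the scale is a negative logarithm) and lower numbers for lower potency), where compound 1 gives 6.92. Compound 2 `O=c1[nH]c(=O)c2cc(Sc3ccc4ccccc4c3)ccc2[nH]1` stands clearly lower in this assay, at 5.07, a gap well beyond the usual scatter. Compound 3 `Nc1nc(O)c2c(Sc3ccc4ccccc4c3)cccc2n1` has not been measured; it differs from compound 1 by hydroxy in place of amino on an aromatic carbon. Within the data shown here, no measured pair shows this kind of change, so the expectation rests on the two values alone: the change is expected to lower potency in this assay, by a number 1.42 log units lower from compound 1 to compound 3 (beyond the scatter), beyond the scatter. Compound 3 is estimated at 5.5, between 4.7 and 6.3.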

Compound 3, logarithm of the reciprocal of the active concentration, log(1/C): 6.15
The estimate for compound 3 lay 0.65 log units below the measured number, within the range that was stated.
By their numbers in this assay, from the lowest: compound 2; then compound 3; then compound 1.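

Putting hydroxy in place of amino on this aromatic carbon, next to the ring nitrogen, gives a number 0.77 log units lower from compound 1 to compound 3 (beyond the scatter) in this assay. Compound 1 and compound 3 differ in this one place only, so this loss belongs to this single exchange, and it gives the first direct measure of what the amino group at this position is worth on this read-out.

Going by these compounds, whether a methoxy group or a methylamino group at this place would give a different value stays open, as does the same exchange at the other amino group. No available evidence bears on what lies behind the loss.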